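The compounds below may be only part of what the source reports. "The series", "measured", "known", "first", "only" and "open" are said of these compounds alone.

Of the compounds shown here, two have a measured value so far in a functional assay on HCT-116 cells (Homo sapiens) for inhibition, read by MTT assay, with a stated time of 48 h (on this read-out higher numbers stand for weaker inhibition and lower numbers for stronger inhibition), of this series. Compound 1 (`COc1ccc(CN(C(=O)C=C(C)C)c2cc(OC)c(OC)c(OC)c2)cc1O`) gives 290 nM there, while compound 2 (`C/C=C/C(=O)N(Cc1ccc(OC)c(Br)c1)c1cc(OC)c(OC)c(OC)c1`) gives 2800 nM and holds the higher of the two numbers, the weaker inhibition, by a gap beyond the scatter. Compound 3 (`C/C=C/C(=O)N(Cc1ccc(OC)c(F)c1)c1cc(OC)c(OC)c(OC)c1`) is compound 2 with a single change (fluoro in place of bromo on an aromatic carbon), fluoro in place of bromo on an aromatic carbon, ortho to a methoxy group and meta to a large group. Among the measured compounds shown here, no measured pair shows this change on its own. Starting from compound 2 at 2800 nM only a small shift toward stronger inhibition is expected in this assay and it should stay within the scatter. The estimated size is a 1.6-fold lower number from compound 2 to compound 3 (0.19 log units; within the scatter) on this reasoning. For compound 3 the expected value is 1800 nM with an estimated range of 600 nM to 6000 nM in this read-out.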

Compound 3, half-maximal inhibitory concentration: 1160 nM
Beside the measured number, compound 3's estimate is 1.6-fold (0.19 log units) above it, within the range that was stated.
By their numbers in this assay, from the lowest: compound 1; then compound 3; then compound 2.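

In this assay, replacing bromo with fluoro on this aromatic carbon, ortho to a methoxy group and meta to a large group, gives a 2.4-fold lower number from compound 2 to compound 3 (0.38 log units; beyond the scatter). Among the compounds shown here, this is the first comparison that isolates a single change, and it shows that the halogen at this position affects the read-out, with the 3-fluoro-4-methoxyphenyl compound giving modestly stronger inhibition than its 3-bromo-4-methoxyphenyl counterpart. No evidence at hand bears on why the step occurs.

Compound 1 differs from compound 3 in more than one place, so it cannot show whether the same step would hold with the acyl chain of compound 1. On these data alone, how chloro, a hydroxyl or an amine on this same carbon would compare with bromo and fluoro also remains open.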